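This account rests on a few compounds, and the source may have more. Where it says the series, first, only, none or still open, it means among the compounds named here.

Series notes. In an ADME assay on cells (Homo sapiens) for cytotoxicity, read by polymerase chain reaction, with a stated time of 3 days (a higher number here means that more compound is tolerated, a lower number that less compound is tolerated), compound 1 `CCOCCNc1nc(C)c(-c2nc3ccccc3s2)c(N[C@@H]2C[C@H](CO)[C@@H](O)[C@H]2O)n1` gives 18000 nM. Compound 2 `CCOC(=O)NCCNc1nc(C)c(-c2nc3ccccc3s2)c(N[C@@H]2C[C@H](CO)[C@@H](O)[C@H]2O)n1` gives 12000 nM in this assay, and the step runs a 1.5-fold lower number from compound 1 to compound 2 (0.18 log units; within the scatter). Compound 3 `Cc1nc(Nc2ccccc2)nc(N[C@@H]2C[C@H](CO)[C@@H](O)[C@H]2O)c1-c1nc2ccccc2s1` returns > 25000 nM in this assay, which is a limit of the assay rather than a number, see (the limit of > 25000 nM in this assay, at which 1 of the 3 values shown sits). Compound 3 therefore stands only as a limit among the values shown. The two steps that change the group on this nitrogen read an at least 1.3-fold higher number from compound 1 to compound 3 (0.14 log units; that floor lies within the scatter) and an at least 2.0-fold higher number from compound 2 to compound 3 (0.31 log units; beyond the scatter). Compound 4 `Cc1nc(NCc2cccnc2)nc(N[C@@H]2C[C@H](CO)[C@@H](O)[C@H]2O)c1-c1nc2ccccc2s1` is not yet measured and differs from compound 3 by (pyridin-3-yl)methyl in place of phenyl on a nitrogen on an aromatic ring, keeping an aromatic ring on that nitrogen. The expected step is a number no higher from compound 3 to compound 4 (the limit leaves the size open), none beyond the scatter. Compound 4 is expected at 25000 nM, estimated between 10000 nM and 60000 nM.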

Compound 4, half-maximal cytotoxic concentration: 5000 nM
Beside the measured number, compound 4's estimate is 5.0-fold (0.70 log units) above it, outside the stated range (below it).
By their numbers in this assay, from the lowest: compound 4; then compounds 2 and 1 (each within the scatter of the next). At a limit, above all of these: compound 3.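

In this assay, for the compounds shown here, the group on this nitrogen matters more than the earlier steps showed, and an aromatic ring there does not by itself keep the number high: the change runs an at least 5.0-fold lower number from compound 3 to compound 4 (0.69 log units; beyond the scatter). Compound 4 also sits lower than both chain compounds, with a 2.4-fold lower number from compound 2 to compound 4 (0.38 log units; beyond the scatter) and a 3.6-fold lower number from compound 1 to compound 4 (0.56 log units; beyond the scatter). Compound 3 stands only at a limit, so the size of its step remains a floor: the limit of > 25000 nM in this assay, at which 1 of the 4 values shown sits.

The compounds shown do not separate the effect of the ring nitrogen from that of the extra chain carbon. Benzyl on this nitrogen would separate the two.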